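This account rests on a few compounds, and the source may have more. Where it says the series, first, only, none or still open, it means among the compounds named here.

Compound 1 `COc1cc(N)c(Cl)cc1C(=O)NC1CCNCC1` is the shared core on which the other two compounds are built. In a functional assay on HEK293 cells for activation of 5-hydroxytryptamine receptor 4 (Homo sapiens), read by cAMP accumulation (a higher number here means a larger maximal response, a lower number a smaller maximal response), compound 1 gives > 100%, which is a limit of the assay rather than a number. Compound 2 `COc1cc(N)c(Cl)cc1C(=O)NC1CCN(CCCCCCCCS(=O)(=O)O)CC1` carries the same core with a longer substituent on the ring nitrogen. In this assay compound 2 likewise gives > 100%, again a limit rather than a number. On the numbers shown, compound 2 therefore stands at the same limit as compound 1, and the limit of > 100% in this assay, at which 2 of the 2 values shown sit, describes this position. Compound 3 `COc1cc(N)c(Cl)cc1C(=O)NC1CCN(CCN2CCCCC2)CC1` differs from compound 2 by piperidin-1-yl in place of 6-sulfohexyl on a saturated chain carbon, two bonds along the chain from an amine nitrogen in a ring. For the measured compounds named here, no step between two measured compounds is available to calibrate this change, so the expected step that the limit leaves unreadable from compound 2 to compound 3 is taken to be none beyond the usual scatter. Compound 3 is accordingly estimated at 105% in this assay, with a range from 85% to 130%.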

Compound 3, intrinsic activity: the largest response reached, in percent of the reference agonist's: > 100%
Compound 3 gave a limit, no number; the forecaster's own chance of this, stated with the estimate: 60%; the middle value does not contradict the limit.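

Compound 3 gave a limit and not a number, as compound 1 and compound 2 did, so no step among these compounds can be read: the limit of > 100% in this assay, at which 3 of the 3 values shown sit. The compounds shown leave open whether their maximal responses in this assay differ at all, and by how much.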